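Hydroxyethyl in place of methyl on the dipropylamino core

The compounds below may be only part of what the source reports. "The series", "measured", "known", "first", "only" and "open" are said of these compounds alone.

Of the compounds shown here, two carry numbers so far. In an in vitro assay on IMR-32 cells for displacement of a labelled ligand from corticotropin-releasing factor receptor 1 (Homo sapiens) (on this read-out lower numbers stand for stronger inhibition and higher numbers for weaker inhibition), compound 1 `CCCN(CCC)c1c(C)nc(-c2c(C)cc(C)cc2OC)c2ccccc12` gives 6 nM, while compound 2 `CCCN(CCC)c1c(CC)nc(-c2c(C)cc(C)cc2OC)nc1OC` gives 22 nM. Compound 2 therefore holds the higher of the two numbers, with compound 1 the nearer and lower one, and the gap between them lies beyond the usual scatter. For the measured compounds named here, no single-change pair has been measured, so no step size is available to lean on.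

Compound 3 `CCCN(CCC)c1c(CC(C)O)nc(-c2c(C)cc(C)cc2OC)nc1OC` differs from compound 2 in one place: 1-hydroxyethyl in place of methyl on a saturated chain carbon bound to an aromatic carbon. With nothing in the series to set the size of such a change, the working assumption is a small step for compound 3, if anything toward a weaker number, within or just beyond the scatter. For compound 3 the expected value in this assay is 35 nM. The expected step from compound 2 to compound 3 is a 1.6-fold higher number from compound 2 to compound 3 (0.20 log units; within the scatter). For compound 3 the expected range runs from an estimated 10 nM to an estimated 120 nM.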

Compound 3, inhibition constant: 1150 nM
Compound 3: the middle estimate sits 33-fold (1.52 log units) below what was measured; the whole stated range lies below it.
By their numbers in this assay, from the lowest: compound 1; then compound 2; then compound 3.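

In this assay, for the compounds shown here, the change to 1-hydroxyethyl in place of methyl gives a 52-fold higher number from compound 2 to compound 3 (1.72 log units; beyond the scatter) and is the first single-change step. It shows that this place, a saturated chain carbon bound to an aromatic carbon, is far from indifferent to substitution, at least on the core shared by compound 2 and compound 3. No measurement on hand bears on what lies behind the size of this step.

The compounds shown leave open whether the hydroxyl or the added chain length carries the loss, and a plain propyl chain at this place would separate the two. Also open, going by these compounds, is how a methoxy or amine at the end of that chain would read, and whether the same change on the core of compound 1 gives a step of similar size.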